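Methoxy for cyclopropylamino on the shared core

This account rests on a few compounds, and the source may have more. Where it says the series, first, only, none or still open, it means among the compounds named here.

Of the compounds shown here, two have numbers so far. In a functional assay on PC-3 cells (Homo sapiens) for inhibition, read by sulforhodamine B assay, with a stated time of 72 h (a lower number here means a stronger inhibitor, a higher number a weaker inhibitor), compound 1 (`CC(C)CNC(=O)c1c(N)sc(-c2ccc(Cl)cc2)c1-c1ccc(Cl)cc1`) gives 13200 nM and compound 2 (`Nc1sc(-c2ccc(Cl)cc2)c(-c2ccc(Cl)cc2)c1C(=O)NC1CC1`) gives 3680 nM. Compound 2 therefore holds the lower of the two numbers, and the gap lies beyond the scatter.

The next structure is compound 3 (`COC(=O)c1c(N)sc(-c2ccc(Cl)cc2)c1-c1ccc(Cl)cc1`), with methoxy in place of cyclopropylamino on a carbonyl carbon. Among the compounds with values here, one measured step bears on this change, and only indirectly: a 3.6-fold lower number from compound 1 to compound 2 (0.55 log units; beyond the scatter). That step is modest and swaps one group on the amide-type nitrogen for another. Within the data shown here, no measured step removes that nitrogen, so the data fix neither the size nor the direction of the change to methoxy.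

Among the measured compounds shown here, with compound 2 at 3680 nM, the lower of only two numbers, a modest move toward a higher number is the working expectation in this assay. The estimated move is a 2.2-fold higher number from compound 2 to compound 3 (0.34 log units; beyond the scatter), with wide uncertainty. For compound 3 the expected value is 8000 nM, within an estimated range of 2500 nM to 25000 nM.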

Compound 3, half-maximal inhibitory concentration: 2780 nM
Estimate against measurement, compound 3: 2.9-fold (0.46 log units) above; low and high end bracket the measured number.
By their numbers in this assay, from the lowest: compounds 3 and 2 (each within the scatter of the next); then compound 1.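

Methoxy on the carbonyl carbon gives a 1.3-fold lower number from compound 2 to compound 3 (0.12 log units; within the scatter) in this assay, so in this pair the nitrogen of cyclopropylamino, its hydrogen-bond donor and its three-membered ring can all be lost with no readable change. The earlier compounds shown here varied only the group on that nitrogen, whereas methoxy in place of isobutylamino now gives a 4.7-fold lower number from compound 1 to compound 3 (0.68 log units; beyond the scatter) and shows that a number of this size does not depend on an amide nitrogen at this place. Nothing measured on these three compounds accounts for these numbers.

Still open, going by these compounds, is how a free carboxylic acid, a primary amide or a dimethylamino group, which has no hydrogen on its nitrogen, would compare on the same carbonyl carbon. Also open, on these data alone, is whether ethoxy or a longer alkoxy chain would stay with methoxy and cyclopropylamino or move toward isobutylamino, which is the only way to tell whether the weaker number of compound 1 belongs to the longer branched chain alone.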